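Moving the Nitro Group Around the Benzyl Ring

This account rests on a few compounds, and the source may have more. Where it says the series, first, only, none or still open, it means among the compounds named here.

Three compounds share one core and differ only in the group on the saturated chain carbon bound to an oxygen on an aromatic ring. In an assay on CHO cells for displacement of a labelled ligand from Alpha-1A adrenergic receptor (Homo sapiens) (a lower number here means a stronger inhibitor, a higher number a weaker inhibitor), compound 1 `COc1cccc(OC)c1OCCNCCOc1ccccc1OCc1ccccc1C` gives 1.59 nM. Compound 2 `COc1cccc(OC)c1OCCNCCOc1ccccc1OCc1ccccc1[N+](=O)[O-]` gives 7.94 nM, and compound 3 `COc1cccc(OC)c1OCCNCCOc1ccccc1OCc1cccc([N+](=O)[O-])c1` gives 0.316 nM, the lowest of the three. The steps behind these numbers are a 5.0-fold higher number from compound 1 to compound 2 (0.70 log units; beyond the scatter), a 5.0-fold lower number from compound 1 to compound 3 (0.70 log units; beyond the scatter) and a 25-fold lower number from compound 2 to compound 3 (1.40 log units; beyond the scatter), the last being the largest of the set. Compound 4 `COc1cccc(OC)c1OCCNCCOc1ccccc1OCc1ccc([N+](=O)[O-])cc1` carries the next placement of the same group: 4-nitrophenyl in place of 3-nitrophenyl on a saturated chain carbon bound to an oxygen on an aromatic ring. Among the compounds with values here, no measured pair covers this particular move; the only guide is the step from compound 2 to compound 3, which shows that relocating the nitro group on that ring can shift the number widely. Compound 4 is therefore expected to land somewhat weaker than compound 3, with a 3.2-fold higher number from compound 3 to compound 4 (0.50 log units; beyond the scatter), and a broad range is kept around it. The estimate for compound 4 in this assay is 1 nM, between 0.2 nM and 5 nM.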

Compound 4, inhibition constant: 1.26 nM
Compound 4: the middle estimate sits 1.3-fold (0.10 log units) below what was measured; the range from low to high includes it.
By their numbers in this assay, from the lowest: compound 3; then compounds 4 and 1 (each within the scatter of the next); then compound 2.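

In this assay the three nitro placements now form a complete order, with 3-nitrophenyl giving the lowest number, 4-nitrophenyl the next and 2-nitrophenyl the highest. The 4-nitrophenyl group gives a 4.0-fold higher number from compound 3 to compound 4 (0.60 log units; beyond the scatter) and also a 6.3-fold lower number from compound 2 to compound 4 (0.80 log units; beyond the scatter) so the 3-nitrophenyl placement stands apart from both of the others, and the middle placement in this order is well separated from each end. Against the 2-methylphenyl group the step is a 1.3-fold lower number from compound 1 to compound 4 (0.10 log units; within the scatter) so those two groups cannot be told apart here, whereas the other two nitro placements each differ from it beyond the scatter.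

On these data alone, whether a nitrile or a carboxylic acid on the same ring would follow this order of placements stays open. No measurement at hand accounts for the order itself.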